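A few compounds are considered here, and "the series" means these few. Any claim that something is new, unique, unknown or untested is made for them only; others in the source may bear on it.

Compound 1, `Cc1ccc(-c2nc3ccccc3o2)cc1NC(=O)c1cnccc1Cl`: in an ADME assay on HepG2 cells (Homo sapiens) for inhibition, with a stated time of 72 h (a lower number here means that less compound is needed, a higher number that more compound is needed for the effect), compound 1 gives > 25000 nM, which is a limit of the assay and not a number.
Compound 2, `COc1ccc(-c2nc3ccccc3o2)cc1NC(=O)c1cnccc1Cl`: in this assay compound 2 gives > 25000 nM, again a limit and not a number.

Compound 2 therefore stands only at a limit in this assay, and it shares that place with compound 1, since both values sit at the limit of > 25000 nM in this assay, at which 2 of the 2 values shown sit. The step from compound 1 to compound 2, methoxy in place of methyl on an aromatic carbon, is a step that the two limits leave unreadable from compound 1 to compound 2, so its size cannot be read.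

Compound 3, `O=C(Nc1cc(-c2nc3ccccc3o2)ccc1F)c1cnccc1Cl`, is not yet measured. It differs from compound 2 by fluoro in place of methoxy on an aromatic carbon. Going by the values given here, the only measured step that touches this position is the one from compound 1 to compound 2, and because both of its ends sit at the limit of > 25000 nM in this assay, at which 2 of the 2 values shown sit, it offers no size to build on. Nothing measured here points to a step beyond the usual scatter, so the expectation is that compound 3 stays where its two neighbours stand. Compound 3 is thus expected to give about 30000 nM in this assay, with a range from 10000 nM to 100000 nM, most likely reported once more as a limit. That estimate means a step that the limit leaves unreadable from compound 2 to compound 3, expected rather than measured.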

Compound 3, half-maximal effective concentration: > 25000 nM
Compound 3 gave a limit, no number; the forecaster's own chance of this, stated with the estimate: 80%; the middle value does not contradict the limit.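

Compound 3 gives > 25000 nM, which is again a limit of the assay and not a number. The steps among compound 1, compound 2 and compound 3 therefore cannot be read: the limit of > 25000 nM in this assay, at which 3 of the 3 values shown sit. Left open is whether methyl, methoxy or fluoro on that aromatic carbon makes any difference in this assay, and at what concentration, if any, these compounds reach the half-maximal effect.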